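Aryl amine swap on a shared core: weaker growth inhibition expected

This account rests on a few compounds, and the source may have more. Where it says the series, first, only, none or still open, it means among the compounds named here.

Three compounds that share one core were tested in a functional assay on A549 cells (Homo sapiens) for antiproliferative activity, read by spectrophotometry, with a stated time of 2 days; on this read-out lower numbers stand for stronger inhibition of growth and higher numbers for weaker inhibition of growth:

Compound 1 `COc1ccc(Nc2ncc(C(F)(F)F)c(N3Cc4cccc(N(C)S(C)(=O)=O)c4C3)n2)cc1C(F)(F)F`: compound 1 gives > 30000 nM, which is a limit of the assay rather than a number.
Compound 2 `COc1cc(Nc2ncc(C(F)(F)F)c(N3Cc4cccc(N(C)S(C)(=O)=O)c4C3)n2)c(OC)cc1Cl`: compound 2 gives 7300 nM.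
Compound 3 `Cc1ccc(Nc2ncc(C(F)(F)F)c(N3Cc4cccc(N(C)S(C)(=O)=O)c4C3)n2)c(C)c1`: compound 3 gives 20700 nM.

Compound 2 holds the lowest of the two numbers. The step of a 2.8-fold higher number from compound 2 to compound 3 (0.45 log units; beyond the scatter) separates it from compound 3, and the step of an at least 4.1-fold lower number from compound 1 to compound 2 (0.61 log units; beyond the scatter) separates it from compound 1, whose value sits at the limit of > 30000 nM in this assay, at which 1 of the 3 values shown sits.

Compound 4 `CN(c1cccc2c1CN(c1nc(Nc3cc(Cl)cc(C(F)(F)F)c3)ncc1C(F)(F)F)C2)S(C)(=O)=O` differs from compound 2 at the aryl group on the nitrogen: 3-chloro-5-(trifluoromethyl)phenyl in place of 4-chloro-2,5-dimethoxyphenyl on a nitrogen on an aromatic ring. For the measured compounds named here, the steps that bear on this change are an at least 4.1-fold lower number from compound 1 to compound 2 (0.61 log units; beyond the scatter) and a 2.8-fold higher number from compound 2 to compound 3 (0.45 log units; beyond the scatter), in which each other aryl group gave a higher number than the 4-chloro-2,5-dimethoxyphenyl of compound 2. The group entering in compound 4 carries a trifluoromethyl and no methoxy, which places it closer to the aryl group of compound 1 than to that of compound 2. Compound 4 is therefore expected to show a modest step toward weaker inhibition, a 2.7-fold higher number from compound 2 to compound 4 (0.44 log units; beyond the scatter), beyond the scatter. The estimate for compound 4 is 20000 nM, expected to lie between 6000 nM and 60000 nM.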

Compound 4, concentration for 50% growth inhibition: 6700 nM
Compound 4: middle estimate off by 3.0-fold (0.47 log units), on the high side, within the range that was stated.
By their numbers in this assay, from the lowest: compounds 4 and 2 (each within the scatter of the next); then compound 3. At a limit, above all of these: compound 1.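

In this assay, this position on the nitrogen keeps its level without either methoxy group, as a 1.1-fold lower number from compound 2 to compound 4 (0.04 log units; within the scatter) shows, so neither 3-chloro-5-(trifluoromethyl)phenyl nor 4-chloro-2,5-dimethoxyphenyl can be ranked over the other here. A trifluoromethyl on the aryl group therefore does not by itself go with the weaker end of this set, since compound 4 carries one, as does compound 1, and the other two steps to compound 4 are a 3.1-fold lower number from compound 3 to compound 4 (0.49 log units; beyond the scatter) and an at least 4.4-fold lower number from compound 1 to compound 4 (0.65 log units; beyond the scatter). The value of compound 1 is a limit and not a number, so the second of those steps gives only a floor: the limit of > 30000 nM in this assay, at which 1 of the 4 values shown sits.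

Going by these compounds, it remains open whether the chlorine on the aryl groups of compound 2 and compound 4, which those of compound 1 and compound 3 lack, is what sets these two apart, a question that a fluorine or a hydrogen in its place would test. Also open, on these data alone, is whether an aryl group bearing a piperazine, a morpholine or a carboxylic acid would move the number beyond the scatter from compound 2 and compound 4.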